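The source may hold more compounds than are shown below. What is called first, only, known or untested is meant among the compounds shown, and "the series" means these compounds.

Of the compounds shown here, three have been tested so far in a functional assay on NCI-H522 cells (Homo sapiens) for cytotoxicity, read by sulforhodamine B assay, with a stated time of 48 h, tested at 100 nM; a higher number here means a weaker effect of the compound at the concentration tested, a lower number a stronger effect. Compound 1 `COc1cc(C)cc(-c2c(-c3ccnc(-c4ccc(C(C)=O)cc4)c3)cnn2CC#N)c1` gives 76% in this assay, compound 2 `COc1cc(C)cc(-c2nn(CC#N)cc2-c2ccc(-c3cccc(C(C)=O)c3)nc2)c1` gives 68% in this assay, and compound 3 `Cc1cc(O)cc(-c2nn(CC#N)cc2-c2ccnc(-c3ccc(Oc4ccccc4)cc3)c2)c1` gives 87% in this assay. Compound 3 therefore stands with the highest number of the three: its gap to compound 1 and its larger gap to compound 2 both lie beyond the usual scatter, so of these three it shows the weakest effect at the concentration tested.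

The next compound, compound 4 `Cc1cc(O)cc(-c2nn(CC#N)cc2-c2ccnc(-c3ccc(N(C)C)cc3)c2)c1`, shares the core of compound 3 and differs from it in one place: dimethylamino in place of phenoxy on an aromatic carbon. Among the compounds with values here, no pair of measured compounds differs by this same change, so there is no directly comparable step to lean on. The three measured compounds differ from one another in several places at once, and none of them isolates what a dimethylamino group does in place of a phenoxy group. Under these conditions only a cautious expectation can be formed: a step of modest size, not clearly beyond the scatter in either direction. The step expected is a number 7 percentage points lower from compound 3 to compound 4 (within the scatter). For compound 4 the number expected in this assay is 80%, most likely somewhere between 60% and 95%.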

Compound 4, a percentage reported as activity, at one concentration (the size of the read-out at that concentration, not a potency): 75%
Estimate against measurement, compound 4: 5 percentage points above, within the range that was stated.
By their numbers in this assay, from the lowest: compounds 2, 4 and 1 (each within the scatter of the next); then compound 3.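

Within the data shown here, this is the first step here that changes only one place, so a single group can be judged on its own: in this assay the swap of phenoxy for dimethylamino, para to a large group on the aromatic ring of carbon only, gives a number 12 percentage points lower from compound 3 to compound 4 (beyond the scatter) and so a stronger effect at the concentration tested. This position therefore responds to the group placed on it, and the change removes a ring and shrinks the group from 7 heavy atoms to 3, while the counts of hydrogen-bond donors and acceptors stay the same. No measurement shown here explains why the effect grows with this swap.

With a single step, the loss of the ring, the smaller size and the exchange of oxygen for nitrogen at the attachment point all arrive together and cannot be told apart. A methoxy group would keep the oxygen without the ring, and a morpholine ring would keep a ring on nitrogen, so either at this same place would help to separate those three changes.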